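Benzyl for Cyclohexyl on a Two-Armed Core

A few compounds are considered here, and "the series" means these few. Any claim that something is new, unique, unknown or untested is made for them only; others in the source may bear on it.

Measured so far:
compound 1 `O=Cc1ccc(-c2cn3ccnc3c(-c3ccc4ncn(C5CCCCC5)c4c3)n2)cc1` gives 47.5%
compound 2 `O=Cc1ccc(-c2cn3ccnc3c(-c3ccc4ncn(Cc5ccccc5)c4c3)n2)cc1` gives 47.5%
compound 3 `c1cn2cc(-c3ccc4c(c3)ncn4C3CCCCC3)nc(-c3ccc4ncn(C5CCCCC5)c4c3)c2n1` gives 50%

All three were tested in a functional assay on SR cells (Homo sapiens) for inhibition, read by sulforhodamine B assay, with a stated time of 48 h, tested at 10 uM; a lower number here means less inhibition, a higher number more inhibition at the concentration tested (going by the name of the read-out). Compound 1 and compound 2 share one core and differ in a single place: benzyl in place of cyclohexyl on an aromatic nitrogen. That exchange produced no change at the digits printed from compound 1 to compound 2 (within the scatter). Compound 3 carries a different core from compound 1; the difference between the two cores is not broken down here. The three values lie within the usual scatter of one another, so the inhibition in this assay is level across them and none can be singled out as higher or lower.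

Compound 4 `c1ccc(Cn2cnc3ccc(-c4nc(-c5ccc6c(c5)ncn6C5CCCCC5)cn5ccnc45)cc32)cc1` is not yet measured. It differs from compound 3 by benzyl in place of cyclohexyl on an aromatic nitrogen, and the surroundings of the place are described in the same words as for the first pair, so it is the same change made on the second core. Among the measured compounds shown here, the one earlier instance of this change gave no change at the digits printed from compound 1 to compound 2 (within the scatter), and that is the only basis for an expectation. The step is therefore expected to be no change at the digits printed from compound 3 to compound 4 (within the scatter), echoing the earlier one. Compound 4 is estimated at 50% in this assay. A range from 38% to 62% is expected to cover most repeats.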

Compound 4, a percentage reported as inhibition, at one concentration (the size of the read-out at that concentration, not a potency): 94.6%
The estimate for compound 4 lay 44.6 percentage points below the measured number, and the stated range ends below it.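

In this assay, the same exchange of cyclohexyl for benzyl on an aromatic nitrogen gave no change at the digits printed from compound 1 to compound 2 (within the scatter) but a number 44.6 percentage points higher from compound 3 to compound 4 (beyond the scatter) on the second core. So the result of this change did not carry from one core to the other, and the two steps clearly differ: the same change on two cores in this assay, no change at the digits printed (within the scatter) from compound 1 to compound 2 and a number 44.6 percentage points higher (beyond the scatter) from compound 3 to compound 4, 44.6 percentage points apart, beyond the scatter of two such steps. Among the compounds shown here, this shows that the effect of the exchange depends on the rest of the molecule in this small set, but with only two pairs, it gives no general rule for other cores and does not explain the difference.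

As far as these compounds go, it also remains open whether benzyl in place of the cyclohexyl still present in compound 4 would bring a further rise or none, and how a longer chain, an amine or a carboxylic acid on the same nitrogen would behave. From the compounds shown here alone, these figures come from one concentration, so how potent compound 4 is compared with compound 3 also remains open.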